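Para substituent swap on the amide aryl ring

The source may report more compounds than this note shows. Statements on the series, on what has been measured and on what is new or still open speak of the compounds shown alone.

The series shares one core, seen in compound 1 `O=C(CSc1nc(Nc2ccccc2)c2ccccc2n1)Nc1cccc(Cl)c1`, compound 2 `O=C(CSc1nc(Nc2ccccc2)c2ccccc2n1)Nc1cccc([N+](=O)[O-])c1` and compound 3 `O=C(CSc1nc(Nc2ccccc2)c2ccccc2n1)Nc1ccc(Cl)cc1`, and differs only in the aryl group on the amide-type nitrogen. In a functional assay on MGC-803 cells (Homo sapiens) for inhibition, read by MTT assay, with a stated time of 72 h (a lower number here means a stronger inhibitor, a higher number a weaker inhibitor), compound 1 gives 14300 nM, compound 2 gives 28100 nM and compound 3 gives 40400 nM. Compound 3 thus holds the highest of the three numbers: its gap to compound 2 is within the scatter, while a 2.8-fold higher number from compound 1 to compound 3 (0.45 log units; beyond the scatter). Compound 4 `CCc1ccc(NC(=O)CSc2nc(Nc3ccccc3)c3ccccc3n2)cc1` is not yet measured; it differs from compound 3 in ethyl in place of chloro on an aromatic carbon. Within the data shown here, no measured step replaces chloro by ethyl: a 2.0-fold higher number from compound 1 to compound 2 (0.29 log units; within the scatter) exchanges chloro for nitro, and a 2.8-fold higher number from compound 1 to compound 3 (0.45 log units; beyond the scatter) and a 1.4-fold higher number from compound 2 to compound 3 (0.16 log units; within the scatter) exchange one chlorophenyl or nitrophenyl for another. All three are small, so for compound 4 a step in this assay that stays within the scatter is expected, with no firm direction. Compound 4 is therefore estimated at 35000 nM (range 15000 nM to 80000 nM). This corresponds to an expected 1.2-fold lower number from compound 3 to compound 4 (0.06 log units; within the scatter).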

Compound 4, half-maximal inhibitory concentration: > 50000 nM
Compound 4: only a limit was reported (the forecaster's own chance of this, stated with the estimate: 10%); middle value at least 1.4-fold (0.15 log units) from the limit.
By their numbers in this assay, from the lowest: compounds 1, 2 and 3 (each within the scatter of the next, the first and the last beyond it). At a limit, above all of these: compound 4.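

In this assay the reading for compound 4 is a limit of the assay and not a number: the limit of > 50000 nM in this assay, at which 1 of the 4 values shown sits.

Ethyl in place of chloro, para to a large group, gives an at least 1.2-fold higher number from compound 3 to compound 4 (0.09 log units; that floor lies within the scatter), and the change from 3-nitrophenyl gives an at least 1.7-fold higher number from compound 2 to compound 4 (0.25 log units; that floor lies within the scatter), so these two floors neither show nor exclude a real loss. Only an at least 3.4-fold higher number from compound 1 to compound 4 (0.54 log units; beyond the scatter) clears the scatter, which places both the 4-chlorophenyl and the 4-ethylphenyl compound beyond the scatter from the 3-chlorophenyl compound, while compound 2, with its 3-nitrophenyl group, goes against any simple split by position.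

From the compounds shown here alone, the true number for compound 4 remains open, so its steps are known only as floors. Going by these compounds, whether an amino or a methoxy group in place of ethyl on this ring would give a lower number also stays open.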